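This account rests on a few compounds, and the source may have more. Where it says the series, first, only, none or still open, it means among the compounds named here.

Of the compounds shown here, three have been measured in a functional assay on MCF7 cells (Homo sapiens) for antiproliferative activity, read by MTT assay, with a stated time of 72 h (a lower number here means a stronger inhibitor, a higher number a weaker inhibitor), all of them sharing a closely related core. Compound 1, `O=C1Nc2c(Cl)cccc2/C1=C1/Nc2ccccc2C1=O`, reaches only the limit of this assay, > 100000 nM, which is a limit rather than a number, as the limit of > 100000 nM in this assay, at which 1 of the 3 values shown sits, records. Compound 2, `O=C1NC(=O)/C(=C2/C(=O)Nc3ccccc32)N1`, gives 94600 nM in this assay. Compound 3, `O=C1NC(=S)N/C1=C1\C(=O)Nc2ccccc21`, gives 87800 nM in this assay, the lowest of the two numbers shown, though its gap to compound 2 is within the usual scatter of repeated measurements, so the two cannot be told apart.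

Compound 4, `O=C1NC(=S)N/C1=C1\C(=O)Nc2c(Br)cccc21`, is not yet measured. It differs from compound 3 in one place: bromo in place of hydrogen on an aromatic carbon. Within the data shown here, no step between two measured compounds shows what such a change does here, so the expectation rests on compound 3 alone. The step from compound 3 to compound 4 in this assay is expected to be small, in either direction, not clearly beyond the scatter. For compound 4 the estimated value is 60000 nM, expected to fall between 20000 nM and 180000 nM.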

Compound 4, half-maximal inhibitory concentration: 51000 nM
For compound 4 the middle estimate is 1.2-fold (0.07 log units) above the measured one; measured number inside the range.
By their numbers in this assay, from the lowest: compounds 4, 3 and 2 (each within the scatter of the next). At a limit, above all of these: compound 1.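

Among these compounds, the first step at a single place, bromo in place of hydrogen on an aromatic carbon, reads in this assay as a 1.7-fold lower number from compound 3 to compound 4 (0.24 log units; within the scatter). Among the compounds shown here, this shows that a bromo group on this carbon, ortho to a fused ring and meta to a fused ring on the six-membered aromatic ring of carbon only, gives a number that cannot be told apart from the one with hydrogen, something the earlier compounds could not show. No measurement shown gives a cause for this step.

As far as these compounds go, whether another group at this position, such as an amine, a carboxylic acid or a longer chain, would give a step beyond the scatter stays open. Also open, from the compounds shown here alone, is what a bromo group would do on the other aromatic carbons of that ring.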